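A few compounds are considered here, and "the series" means these few. Any claim that something is new, unique, unknown or untested is made for them only; others in the source may bear on it.

Among the compounds with values here, in a functional assay on SKHep cells (Homo sapiens) for antiproliferative activity, read by MTT assay, with a stated time of 12 h (a higher number here means a weaker inhibitor, a lower number a stronger inhibitor), compound 1 `COc1cc(OC)c2c(=O)cc(/C=C/c3ccc([N+](=O)[O-])cc3)oc2c1` gives 22000 nM, which is the only plain number available here. Compound 2 `COc1ccc2oc(/C=C/c3ccc(OC(F)(F)F)cc3)cc(=O)c2c1` reaches only a limit of the assay, > 40000 nM, and so yields no number. Of the two entries shown, compound 1 therefore stands as the one with a measured value, while the other sits at the limit of > 40000 nM in this assay, at which 1 of the 2 values shown sits.

Compound 3 `COc1cc(OC)c2c(=O)cc(/C=C/c3ccccc3)oc2c1` has not yet been measured. It differs from compound 1 by hydrogen in place of nitro on an aromatic carbon of a six-membered aromatic ring of carbon only, para to a large group. Within the data shown here, no pair of measured compounds here differs in only one place, so there is no measured step of this kind to lean on, and the size of the change can only be guessed. The loss of the nitro group is expected to shift potency by a small amount, if at all, most likely toward a slightly weaker inhibitor. Compound 3 is thus expected to give 30000 nM, with a range from 10000 nM to 80000 nM. This expectation amounts to a step of a 1.4-fold higher number from compound 1 to compound 3 (0.13 log units; within the scatter), which is estimated to lie close to the usual scatter.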

Compound 3, half-maximal inhibitory concentration: 26000 nM
Compound 3: middle estimate off by 1.2-fold (0.06 log units), on the high side; low and high end bracket the measured number.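

In this assay, within the data shown here, replacing the nitro group with hydrogen on the aromatic ring, para to a large group, gives a 1.2-fold higher number from compound 1 to compound 3 (0.07 log units; within the scatter), the first measured change in one place in this set. At this position, a group of three heavy atoms can therefore give way to a single hydrogen atom with no difference that can be told apart from the spread of repeated measurements, so the activity of compound 1 in this assay does not depend on the nitro group. Nothing measured here explains why the two compounds read alike.

Going by these compounds, this single step compares only nitro and hydrogen, so it remains open whether an amine or a carboxylic acid at the same position would bring a change larger than the usual spread of the assay. On these data alone, it also says nothing about changes elsewhere in the molecule, such as swapping the methoxy groups on the shared core for longer chains, and so how the rest of the structure bears on activity remains unknown.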